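The source may hold more compounds than are shown below. What is called first, only, known or untested is meant among the compounds shown, and "the series" means these compounds.

Measured in a functional assay on SMMC-7721 cells (Homo sapiens) for antiproliferative activity, read by CCK-8 assay, with a stated time of 48 h; on this read-out lower numbers stand for stronger inhibition and higher numbers for weaker inhibition:

compound 1 `CCCCSc1n[nH]c(-n2[se]c3ccccc3c2=O)n1` gives 16800 nM
compound 2 `O=c1c2ccccc2[se]n1-c1nc(SCc2ccc(F)cc2)n[nH]1` gives 46100 nM
compound 3 `CC(C)Sc1n[nH]c(-n2[se]c3ccccc3c2=O)n1` gives 6010 nM

Compound 3 stands lowest of the three numbers in this assay; its nearest neighbour is compound 1, with a 2.8-fold lower number from compound 1 to compound 3 (0.45 log units; beyond the scatter), and the furthest is compound 2, with a 7.7-fold lower number from compound 2 to compound 3 (0.88 log units; beyond the scatter). Among the measured pairs, a 2.7-fold higher number from compound 1 to compound 2 (0.44 log units; beyond the scatter) shows the change from a straight chain to 4-fluorobenzyl on the sulfur.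

Compound 4 `CCCCCSc1n[nH]c(-n2[se]c3ccccc3c2=O)n1` is the next member: pentyl in place of isopropyl on a sulfur. The step that bears most directly on it is the one between the branched three-carbon group and the straight four-carbon chain, a 2.8-fold lower number from compound 1 to compound 3 (0.45 log units; beyond the scatter), which ran downward on going from the straight chain to the branched one. Compound 4 carries a straight chain one carbon longer than that of compound 1, so a step upward from compound 3 of at least that size is expected, and the number for compound 4 is estimated to sit near or somewhat above that of compound 1. For compound 4 this is expected to mean a 3.3-fold higher number from compound 3 to compound 4 (0.52 log units; beyond the scatter). The expected value for compound 4 is 20000 nM, within an estimated range of 7000 nM to 60000 nM.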

Compound 4, half-maximal inhibitory concentration: 31400 nM
Compound 4: middle estimate off by 1.6-fold (0.20 log units), on the low side, and the stated range covers the measured number.
By their numbers in this assay, from the lowest: compound 3; then compounds 1, 4 and 2 (each within the scatter of the next, the first and the last beyond it).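

In this assay, pentyl on the sulfur stands clearly apart from isopropyl (a 5.2-fold higher number from compound 3 to compound 4 (0.72 log units; beyond the scatter)), so the isopropyl of compound 3 now lies beyond the scatter of all three other groups on that sulfur. Butyl and pentyl cannot be told apart (a 1.9-fold higher number from compound 1 to compound 4 (0.27 log units; within the scatter)), and neither can pentyl and 4-fluorobenzyl (a 1.5-fold lower number from compound 2 to compound 4 (0.17 log units; within the scatter)), although butyl and 4-fluorobenzyl themselves remain separated (a 2.7-fold higher number from compound 1 to compound 2 (0.44 log units; beyond the scatter)). Among these compounds, with isopropyl as the only branched group, branching and chain length cannot yet be separated.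

Still open, on these data alone, is whether ethyl, tert-butyl or cyclopropyl on the sulfur would stay near compound 3 (6010 nM). No available evidence accounts for the differences among these sulfur groups.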